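The source may report more compounds than this note shows. Statements on the series, on what has been measured and on what is new or still open speak of the compounds shown alone.

Working notes on the hydroxyamino pyranone amide series.

Compound 1 `O=C(Nc1ccccc1)c1c(NO)cc(-c2ccccc2)oc1=O` is the parent of the set; in an ADME assay on Huh-7 cells (Homo sapiens) for cytotoxicity, read by a luciferase reporter and WST assay, with a stated time of 3 days (on this read-out lower numbers stand for higher toxicity in this test and higher numbers for lower toxicity in this test), compound 1 gives 11600 nM. Compound 2 `COc1ccc(-c2cc(NO)c(C(=O)Nc3ccccc3)c(=O)o2)cc1` carries a methoxy in place of hydrogen on an aromatic carbon, and in this assay compound 2 gives 16200 nM; the step of a 1.4-fold higher number from compound 1 to compound 2 (0.15 log units; within the scatter) lies within the scatter. Compound 3 `O=C(Nc1ccc(F)cc1)c1c(NO)cc(-c2ccccc2)oc1=O` carries a fluoro in place of hydrogen on an aromatic carbon. In this assay compound 3 gives > 20000 nM, which is a limit of the assay and not a number, so compound 3 is placed only by the limit of > 20000 nM in this assay, at which 1 of the 3 values shown sits, and by the step of an at least 1.7-fold higher number from compound 1 to compound 3 (0.23 log units; that floor lies within the scatter); that floor lies within the scatter.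

Compound 4 `O=C(Nc1ccc(Br)cc1)c1c(NO)cc(-c2ccccc2)oc1=O` is not yet measured. It differs from compound 3 by bromo in place of fluoro on an aromatic carbon. Among the compounds with values here, no measured step involves a halogen-for-halogen swap, so the bearing steps are the two above, both within the scatter. On that basis the step of a number no higher from compound 3 to compound 4 (the limit leaves the size open) is expected to stay within the scatter. Compound 4 is therefore estimated at 20000 nM in this assay. For compound 4 the range is expected to run from 10000 nM to 40000 nM, with a fair chance that only a limit is reported again.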

Compound 4, half-maximal cytotoxic concentration: > 20000 nM
Compound 4: a limit, no number (the forecaster's own chance of this, stated with the estimate: 55%); the middle value sits exactly at the limit.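

Working notes, bromo result. In this assay compound 4 gives > 20000 nM, which is a limit of the assay and not a number, so the change from 4-fluorophenyl to 4-bromophenyl cannot be sized and the step between compound 3 and compound 4 cannot be read. Measured from the parent, bromo in place of hydrogen gives an at least 1.7-fold higher number from compound 1 to compound 4 (0.23 log units; that floor lies within the scatter), the same floor as fluoro gives with an at least 1.7-fold higher number from compound 1 to compound 3 (0.23 log units; that floor lies within the scatter), so neither floor shows a change beyond the scatter. What is new is that a second halogen at this place, para to a large group, also ends at the limit of the assay: the limit of > 20000 nM in this assay, at which 2 of the 4 values shown sit.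

The compounds shown leave open how far past the limit compound 3 and compound 4 lie, and so whether the two halogens differ at all in this assay. Also open, going by these compounds, is whether a non-halogen group at this place, such as an amine or a carboxylic acid, would give a readable number.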